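A few compounds are considered here, and "the series" means these few. Any claim that something is new, unique, unknown or untested is made for them only; others in the source may bear on it.

Measured so far:
compound 1, `CC(C(=O)N1CCC(F)(F)CC1)N1CCN(S(=O)(=O)c2ccc(C(C)(C)C)cc2)CC1`: > 40000 nM
compound 2, `C[C@@H](C(=O)N1CCc2ccccc2C1(C)C)N1CCN(S(=O)(=O)c2ccc(C(C)(C)C)cc2)CC1`: 26000 nM

Both were tested in an ADME assay on HepG2 cells (Homo sapiens) for inhibition, with a stated time of 48 h; on this read-out lower numbers stand for an effect already at smaller amounts and higher numbers for an effect only at larger amounts of compound. For compound 1 the result is not a number but a limit of the assay, namely (the limit of > 40000 nM in this assay, at which 1 of the 2 values shown sits). Compound 2 gives 26000 nM in this assay. The unmeasured compound 3, `CC(C(=O)N1CCc2ncccc2C1)N1CCN(S(=O)(=O)c2ccc(C(C)(C)C)cc2)CC1`, differs from compound 1 in one place: a group of 10 heavy atoms (8 carbon, 2 nitrogen; one six-membered non-aromatic ring with 1 hetero atom, one six-membered aromatic ring with 1 hetero atom) in place of a group of 8 heavy atoms (5 carbon, 1 nitrogen, 2 fluorine; one six-membered non-aromatic ring with 1 hetero atom), on a carbonyl carbon. Among the compounds with values here, no measured step of this kind exists to anchor the change, so the step of an at least 1.1-fold lower number from compound 1 to compound 3 (0.05 log units; that floor lies within the scatter) is expected to stay within the usual scatter. Compound 3 is therefore estimated at 35000 nM, within a range from 12000 nM to 100000 nM.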

Compound 3, half-maximal effective concentration: > 40000 nM
Compound 3 was reported as a limit; the forecaster's own chance of this, stated with the estimate: 55%; middle value at least 1.1-fold (0.05 log units) from the limit.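

Compound 1 and compound 3 both stop at a limit of the assay, so no step between them can be read: the limit of > 40000 nM in this assay, at which 2 of the 3 values shown sit.

As far as these compounds go, whether replacing the 4,4-difluoropiperidin-1-yl group with the group in compound 3 changes the effect at all remains open.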